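Removing One Methoxy Group from Compound 2

A few compounds are considered here, and "the series" means these few. Any claim that something is new, unique, unknown or untested is made for them only; others in the source may bear on it.

Compound 1 `COc1cc(-c2cc(/C=C/C(=O)c3ccc(Cl)c(Cl)c3)[nH]n2)cc(OC)c1OC` gives 16900 nM in a functional assay on CAKI-1 cells (Homo sapiens) for inhibition, read by sulforhodamine B assay, with a stated time of 48 h; a higher number here means a weaker inhibitor of growth, a lower number a stronger inhibitor of growth.
Compound 2 `COc1ccc(C(=O)/C=C/c2cc(-c3cc(OC)c(OC)c(OC)c3)n[nH]2)cc1OC` gives 2200 nM in this assay.

Among the measured compounds shown here, compound 2 holds the lower of the two numbers; the only measured step, a 7.7-fold lower number from compound 1 to compound 2 (0.89 log units; beyond the scatter), came from 3,4-dimethoxyphenyl in place of 3,4-dichlorophenyl on a carbonyl carbon. Compound 3 `COc1ccc(C(=O)/C=C/c2cc(-c3cc(OC)c(OC)c(OC)c3)n[nH]2)cc1` differs from compound 2 by hydrogen in place of methoxy on an aromatic carbon. For the measured compounds named here, no measured step removes a single methoxy group, so that one step shows only that this ring tolerates a larger change. For compound 3 a small step towards a higher number is expected, a 1.6-fold higher number from compound 2 to compound 3 (0.20 log units; within the scatter). Compound 3 is estimated at 3500 nM, within 1200 nM to 12000 nM.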

Compound 3, concentration for 50% growth inhibition: 2340 nM
The estimate for compound 3 lay 1.5-fold (0.17 log units) above the measured number; the measured number falls inside the stated range.
By their numbers in this assay, from the lowest: compounds 2 and 3 (each within the scatter of the next); then compound 1.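

In this assay the loss of this methoxy group gives only a 1.1-fold higher number from compound 2 to compound 3 (0.03 log units; within the scatter), so 3,4-dimethoxyphenyl and 4-methoxyphenyl cannot be told apart here and this group is not needed to hold the number. The advantage over 3,4-dichlorophenyl also remains with a single methoxy group on the ring, at a 7.2-fold lower number from compound 1 to compound 3 (0.86 log units; beyond the scatter). Nothing available here explains either step. The compounds shown leave open whether the number holds when the remaining methoxy group gives way to hydrogen, or when an amine or a carboxylic acid stands in its place.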